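The compounds below may be only part of what the source reports. "The series", "measured", "known", "first", "only" and "open" are said of these compounds alone.

Measured compounds:
compound 1 `COc1cc(/C=C/C(=O)c2cccc(-n3cc(-c4ccccc4)[nH]c3=O)c2)ccc1O` — 2520 nM
compound 2 `O=C(/C=C/c1cccc(O)c1)c1cccc(-n2cc(-c3ccccc3)[nH]c2=O)c1` — 2820 nM
compound 3 `COc1cc(/C=C/C(=O)c2cccc(-n3cc(-c4ccccc4)[nH]c3=O)c2)cc(OC)c1OC` — 3260 nM

The three compounds share one core and differ only in the aryl ring at the far end of the double-bonded chain. In a functional assay on PC-3 cells (Homo sapiens) for inhibition (on this read-out lower numbers stand for stronger inhibition of growth and higher numbers for weaker inhibition of growth), compound 1 stands level with its two neighbours: the step of a 1.1-fold higher number from compound 1 to compound 2 (0.05 log units; within the scatter) is within the scatter, and compound 3 gives a number that also lies within the scatter of compound 1, so none of the three can be called stronger or weaker than another.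

Compound 4 `COc1ccc(-c2cn(-c3cccc(C(=O)/C=C/c4ccc(O)c(OC)c4)c3)c(=O)[nH]2)cc1` keeps the chain and its 4-hydroxy-3-methoxyphenyl end exactly as in compound 1 and changes a different part of the molecule: methoxy in place of hydrogen on an aromatic carbon, read one bond further out as phenyl becoming 4-methoxyphenyl. Within the data shown here, no measured pair alters this phenyl; the only measured step, from compound 1 to compound 2, sits on the other ring and stayed within the scatter. The measured data therefore offer no hint of a change beyond the scatter for this new variation. Compound 4 is expected to give a number close to compound 1, with the expected step of a 1.0-fold lower number from compound 1 to compound 4 (0.00 log units; within the scatter). The estimate for compound 4 is 2500 nM, expected to fall between 1100 nM and 5700 nM.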

Compound 4, concentration for 50% growth inhibition: 3050 nM
Compound 4: the middle estimate sits 1.2-fold (0.09 log units) below what was measured, within the range that was stated.
By their numbers in this assay, from the lowest: compounds 1, 2, 4 and 3 (each within the scatter of the next).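

Among these compounds, the phenyl on the shared core did not vary among the earlier compounds, so compound 4 gives the first reading at this position. In this assay, methoxy in place of hydrogen on this aromatic carbon, para to a large group, gives a step that stays within the scatter (a 1.2-fold higher number from compound 1 to compound 4 (0.08 log units; within the scatter)), so the 4-methoxyphenyl compound cannot be told apart from its phenyl parent, just as the change at the other end of the molecule could not be told apart earlier (a 1.1-fold higher number from compound 1 to compound 2 (0.05 log units; within the scatter)). No measurement shown here explains this result.

As far as these compounds go, what a different kind of group on this phenyl would do remains open: an amine, a carboxylic acid or a longer chain such as butoxy might move the number beyond the scatter, or might not. Also open is whether the methoxy gives the same result with the 3-hydroxyphenyl end of compound 2 or the trimethoxyphenyl end of compound 3, as it is shown here only with the 4-hydroxy-3-methoxyphenyl end.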